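A few compounds are considered here, and "the series" means these few. Any claim that something is new, unique, unknown or untested is made for them only; others in the source may bear on it.

Measured compounds:
Compound 1 `O=C(NCCCCc1ccccc1)n1c(=O)oc2cc(C3CCOCC3)ccc21` gives 68 nM in an assay on HEK293 cells for inhibition of acid ceramidase (Homo sapiens), read by fluorescence, with stated times of 10 min and 3 h; on this read-out higher numbers stand for weaker inhibition and lower numbers for stronger inhibition.
Compound 2 `O=C(NCCCCc1ccccc1)n1c2c(oc1=O)CNCC2` gives 340 nM in this assay.
Compound 3 `CN1CCC(c2ccc3c(c2)oc(=O)n3C(=O)NCCCCc2ccc(F)cc2)CC1` gives 94 nM in this assay.

Among the three numbers, compound 3 holds the second highest. Its nearest neighbour is compound 1, whose number lies within the usual scatter of that of compound 3, so the two cannot be told apart on this evidence. Compound 2 stands furthest away, with a number beyond the scatter above that of compound 3.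

Compound 4 `CC(C)CNC(=O)n1c(=O)oc2cc(C3CCN(C)CC3)ccc21` differs from compound 3 in a single place: isopropyl in place of 3-(4-fluorophenyl)propyl on a saturated chain carbon bound to an amide-type nitrogen. Among the measured compounds shown here, no step between two measured compounds resembles this change. Every measured compound carries a six-membered aromatic ring at the end of the chain on the amide-type nitrogen, and compound 4 would be the first without one, so the expectation rests on the structural change alone rather than on a comparable step.

On that basis compound 4 is expected to inhibit more weakly than compound 3, with a step beyond the scatter towards a higher number. The expected step from compound 3 to compound 4 is a 6.4-fold higher number from compound 3 to compound 4 (0.81 log units; beyond the scatter). Compound 4 is estimated to give 600 nM, with a likely range from 150 nM to 3000 nM.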

Compound 4, half-maximal inhibitory concentration: 166 nM
Estimate against measurement, compound 4: 3.6-fold (0.56 log units) above; measured number inside the range.
By their numbers in this assay, from the lowest: compounds 1, 3 and 4 (each within the scatter of the next, the first and the last beyond it); then compound 2.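

In this assay, isopropyl in place of 3-(4-fluorophenyl)propyl on a saturated chain carbon bound to an amide-type nitrogen gives a step that can be read directly (a 1.8-fold higher number from compound 3 to compound 4 (0.25 log units; within the scatter)), so compound 3 and compound 4 cannot be told apart on this evidence. Among the compounds shown here, on this core, then, a number in this range does not depend on the six-membered aromatic ring of carbon only: that ring leaves with the whole group of 10 heavy atoms, isopropyl brings 3 heavy atoms and no ring, and the earlier compounds, which all carry such a ring, could not show this. No measured evidence here accounts for this result.

The compounds shown leave open whether a straight butyl chain, a cyclohexyl ring, or a chain ending in an amine or a carboxylic acid would read alike at this place, and whether the fluorine contributes anything apart from the ring that carries it. They also leave open whether isopropyl would give a comparable step on the cores of compound 1 and compound 2.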